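Thienyl enone series: swapping the aryl on the alkene

The source may hold more compounds than are shown below. What is called first, only, known or untested is meant among the compounds shown, and "the series" means these compounds.

Measured compounds:
compound 1 `Cc1ccsc1/C=C(/SCc1ccc(Cl)cc1)C(=O)c1ccc(Cl)cc1`, 50000 nM
compound 2 `Cc1ccsc1/C=C(/SCc1ccc(F)cc1)C(=O)c1ccc(Cl)cc1`, 50000 nM
compound 3 `Cc1ccsc1/C=C(/SCc1ccc(Cl)cc1Cl)C(=O)c1ccc(Cl)cc1`, 10000 nM

Compound 1 is level with compound 2 in a functional assay on DU-145 cells (Homo sapiens) for inhibition, read by trypan blue exclusion, with a stated time of 96 h; a lower number here means a stronger inhibitor of growth, a higher number a weaker inhibitor of growth; together they give the highest numbers of the three, and compound 3 sits a step below them, a 5.0-fold lower number from compound 1 to compound 3 (0.70 log units; beyond the scatter). The only variations covered so far sit on the benzylthio group: no change at the digits printed from compound 1 to compound 2 (within the scatter), a 5.0-fold lower number from compound 2 to compound 3 (0.70 log units; beyond the scatter).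

Compound 4 `O=C(/C(=C\c1c(O)cc(O)cc1O)SCc1ccc(Cl)cc1)c1ccc(Cl)cc1` changes a different part of compound 1: 2,4,6-trihydroxyphenyl in place of 3-methylthiophen-2-yl on a double-bonded chain carbon bound to a double-bonded chain carbon. Among the compounds with values here, no measured step touches this position, so the size and direction of the shift in this assay cannot be read from the three numbers. The expectation for compound 4 is therefore anchored on compound 1 with a wide range, a 1.7-fold lower number from compound 1 to compound 4 (0.22 log units; within the scatter), giving an estimated 30000 nM (range 5000 nM to 100000 nM).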

Compound 4, concentration for 50% growth inhibition: > 100000 nM
Compound 4: no number, only a limit; the forecaster's own chance of this, stated with the estimate: 30%; middle value at least 3.3-fold (0.52 log units) from the limit.
By their numbers in this assay, from the lowest: compound 3; then compounds 1 and 2 (each within the scatter of the next). At a limit, above all of these: compound 4.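

Compound 4 gives > 100000 nM in this assay, and this is a limit of the assay, not a number. Within the data shown here, this is the first reading at the aryl on the alkene, and the swap to 2,4,6-trihydroxyphenyl gives an at least 2.0-fold higher number from compound 1 to compound 4 (0.30 log units; that floor lies within the scatter), so no gain in growth inhibition appears and a true loss is not established. The benzylthio changes gave a readable spread, whereas this change reaches the assay's ceiling: the limit of > 100000 nM in this assay, at which 1 of the 4 values shown sits.

The ring swap and the hydroxyl groups change together here, so their contributions stay unseparated. Open, going by these compounds, is how an unsubstituted phenyl or a 4-aminophenyl group at this place would read against compound 1.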